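The compounds below may be only part of what the source reports. "The series", "measured", "known", "first", "only" and "open" are said of these compounds alone.

Measured so far:
compound 1, `O=C1C[C@@H]2CCCC[C@@H]2[C@H]1/C=C/c1ccc(-c2cccc(F)c2)cn1`: 1100 nM
compound 2, `OC1C[C@@H]2CCCC[C@@H]2[C@H]1/C=C/c1ccc(-c2cccc(F)c2)cn1`: 220 nM
compound 3, `Fc1cccc(-c2ccc(/C=C/[C@H]3C(OCc4ccccc4)C[C@@H]4CCCC[C@@H]43)nc2)c1`: 280 nM

In an assay on cell membranes for displacement of a labelled ligand from proteinase-activated receptor 1 (Homo sapiens), read by scintillation counting, with a stated time of 60 min (on this read-out higher numbers stand for weaker inhibition and lower numbers for stronger inhibition), compound 1 gives 1100 nM, compound 2 gives 220 nM and compound 3 gives 280 nM. Among these three numbers compound 3 stands second highest; compound 2 is its nearest neighbour and lies within the scatter of it, while compound 1 lies furthest away, beyond the scatter.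

Compound 4, `CN(C)C(=S)OC1C[C@@H]2CCCC[C@@H]2[C@H]1/C=C/c1ccc(-c2cccc(F)c2)cn1`, has not yet been measured in this assay. Compared with compound 3 the change is: a group of 5 heavy atoms (3 carbon, 1 nitrogen, 1 sulfur; no ring) in place of a group of 7 heavy atoms (7 carbon; one six-membered aromatic ring of carbon only), on an oxygen on a saturated carbon. Within the data shown here, one measured step bears on this place on the oxygen, namely a 1.3-fold higher number from compound 2 to compound 3 (0.10 log units; within the scatter), a small move that stays within the scatter. The two values of compound 1 and compound 3 concern a different change and give no further guide here. Among the measured compounds shown here, with only one step at this oxygen to go on, and that one small, a step of no more than modest size is expected for compound 4, a 1.3-fold higher number from compound 3 to compound 4 (0.10 log units; within the scatter). Compound 4 is therefore estimated to give 350 nM in this assay, with a range from 120 nM to 1000 nM.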

Compound 4, half-maximal inhibitory concentration: 120 nM
Beside the measured number, compound 4's estimate is 2.9-fold (0.46 log units) above it; the measured number falls inside the stated range.
By their numbers in this assay, from the lowest: compounds 4, 2 and 3 (each within the scatter of the next, the first and the last beyond it); then compound 1.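

In this assay, among these compounds, the exchange of benzyl for the ring-free group of 5 heavy atoms on this oxygen gives a 2.3-fold lower number from compound 3 to compound 4 (0.37 log units; beyond the scatter), the first step at this place to pass beyond the scatter, so the group carried here can shift the number. Measured against hydrogen on the same oxygen, the new group gives a 1.8-fold lower number from compound 2 to compound 4 (0.26 log units; within the scatter), so hydrogen and this group cannot be told apart, while the benzyl and the new group can. Nothing available explains why the two groups differ.

The compounds shown leave open how an amine or a carboxylic acid on a longer chain would read on this oxygen. They also leave open whether the sulfur of the new group matters, as the matching group with oxygen in its place is not among them.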